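A few compounds are considered here, and "the series" means these few. Any claim that something is new, unique, unknown or untested is made for them only; others in the source may bear on it.

Compound 2 `COc1ccc(/C=C\C(=O)O)c(OCc2cn(-c3ccc(NC(=O)c4ccccc4)cc3)nn2)c1CC=C(C)C`: 42700 nM. Compound 1 `COc1ccc(/C=C\C(=O)O)c(OCc2cn(-c3ccc(CO)cc3)nn2)c1CC=C(C)C`: "not determined" (no result reported).

Within the data shown here, in a functional assay on A549 cells (Homo sapiens) for cytotoxicity, read by MTT assay, with a stated time of 24 h (on this read-out lower numbers stand for stronger inhibition and higher numbers for weaker inhibition), compound 2 gives 42700 nM, and this is the only number in hand; in this assay compound 1 gives "not determined" (no result reported). Compound 3 `COc1ccc(/C=C\C(=O)O)c(OCc2cn(-c3ccc(C#N)cc3)nn2)c1CC=C(C)C` differs from compound 2 in one place: cyano in place of benzamido on an aromatic carbon. Among the measured compounds shown here, no measured step shows what such a change does here, so the step is expected to stay small, either direction, and not clearly beyond the usual scatter; the estimated step is a 1.2-fold higher number from compound 2 to compound 3 (0.07 log units; within the scatter). Compound 3 is therefore expected to give about 50000 nM, with a range from 15000 nM to 160000 nM.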

Compound 3, half-maximal inhibitory concentration: 42200 nM
Compound 3: middle estimate off by 1.2-fold (0.07 log units), on the high side; the measured number falls inside the stated range.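

In this assay, replacing benzamido with cyano on this aromatic carbon, para to a large group, gives a 1.0-fold lower number from compound 2 to compound 3 (0.01 log units; within the scatter). For this pair, then, removing the benzamido ring and the amide hydrogen produces no difference beyond the scatter, even though the entering group is much smaller. Nothing in hand bears on why the two compounds read alike. On these data alone, what an amine or a carboxylic acid would give at this place stays open, as does whether this match extends beyond these two compounds.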